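Shortening the acid chain: what to expect for compound 3

A few compounds are considered here, and "the series" means these few. Any claim that something is new, unique, unknown or untested is made for them only; others in the source may bear on it.

Measured so far in a physicochemical assay for lipophilicity, read by HPLC, at pH 7.4; on this read-out higher numbers stand for higher lipophilicity and lower numbers for lower lipophilicity:
- compound 1 `O=C(O)COc1ccc([C@H]2CC[C@]3(CC2)OOC2(O3)C3CC4CC(C3)CC2C4)cc1`: 2.9
- compound 2 `O=C(O)CCCCOc1ccc([C@H]2CC[C@]3(CC2)OOC2(O3)C3CC4CC(C3)CC2C4)cc1`: 4

Of these two compounds, compound 2 has the higher number, 4, and compound 1 lies below it by more than the scatter. The next compound, compound 3 `O=C(O)c1ccc([C@H]2CC[C@]3(CC2)OOC2(O3)C3CC4CC(C3)CC2C4)cc1`, has not yet been measured. Its difference from compound 2 is carboxy in place of 4-carboxybutoxy on an aromatic carbon, para to a large group.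

Within the data shown here, only one measured step bears on this change: a number 1.10 log units higher from compound 1 to compound 2 (beyond the scatter). That large step also altered the chain carrying the carboxy. Compound 3 has no such chain, so a large move toward lower numbers is expected in this assay, of similar or slightly greater size. The estimated change is a number 1.30 log units lower from compound 2 to compound 3 (beyond the scatter). With a single step as a guide, the estimate is rough. The expected value for compound 3 is 2.7, with an estimated range of 2.1 to 3.3.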

Compound 3, distribution coefficient: 3
Beside the measured number, compound 3's estimate is 0.30 log units below it; the range from low to high includes it.
By their numbers in this assay, from the lowest: compounds 1 and 3 (each within the scatter of the next); then compound 2.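

In this assay, carboxy in place of 4-carboxybutoxy on the aromatic carbon gives a number 1.00 log units lower from compound 2 to compound 3 (beyond the scatter). Carboxy in place of carboxymethoxy gives a number 0.10 log units higher from compound 1 to compound 3 (within the scatter), so among these three compounds the number does not follow chain length step by step: only the 4-carboxybutoxy chain of compound 2 stands apart, while the bare carboxy and the carboxymethoxy chain cannot be told apart. Nothing measured here accounts for this difference.

As far as these compounds go, a carboxypropoxy chain, intermediate in length between carboxymethoxy and 4-carboxybutoxy, would show whether the number climbs gradually or only once the chain reaches its longest form, and that remains open. Also open, from the compounds shown here alone, is how an amine on the same aromatic carbon, in place of the carboxy, would read in this assay.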